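The source may hold more compounds than are shown below. What is called first, only, known or untested is meant among the compounds shown, and "the series" means these compounds.

Measured compounds:

compound 1, `CC(C)c1ccc(-c2nc(SCc3cn(CC(=O)NC(=O)Nc4ccccn4)nn3)nc(Nc3cccc(Cl)c3)c2C#N)cc1`, in a functional assay on B16-F10 cells (Mus musculus) for inhibition, read by MTT assay, with a stated time of 72 h (on this read-out higher numbers stand for weaker inhibition and lower numbers for stronger inhibition), compound 1 gives 1130 nM
compound 2, `COc1ccc(Nc2nc(SCc3cn(CC(=O)NC(=O)Nc4ccccn4)nn3)nc(-c3ccc(C)cc3)c2C#N)cc1`, compound 2 gives 8750 nM
compound 3, `COc1ccccc1Nc1nc(SCc2cn(CC(=O)NC(=O)Nc3ccccn3)nn2)nc(-c2ccc(C)cc2)c1C#N`, compound 3 gives 8580 nM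

Compound 3 holds the second highest of the three numbers. Its nearest neighbour is compound 2, whose number is within the usual scatter of it, so the two cannot be told apart. Compound 1 sits well below both, beyond the scatter, so compound 1 is the stronger inhibitor of the three.

Compound 4, `Cc1ccc(-c2nc(SCc3cn(CC(=O)NC(=O)Nc4ccccn4)nn3)nc(Nc3cccc(Cl)c3)c2C#N)cc1`, has not yet been measured. It differs from compound 3 in one place: 3-chlorophenyl in place of 2-methoxyphenyl on a nitrogen on an aromatic ring.

Only one measured step exists among these compounds, a 1.0-fold lower number from compound 2 to compound 3 (0.01 log units; within the scatter), and it exchanges one methoxyphenyl group for another, so it does not test a chlorophenyl group at all. Compound 1 does carry the 3-chlorophenyl group, but it also differs from compound 4 in the other aryl group, so its low number cannot be attributed to the chlorophenyl alone. The chlorophenyl compound being the strongest measured is the only hint, and it points downward. Compound 4 is therefore expected to show a step of a 2.9-fold lower number from compound 3 to compound 4 (0.46 log units; beyond the scatter) toward a lower number, with wide uncertainty, giving an estimate of 3000 nM, between 900 nM and 9000 nM.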

Compound 4, half-maximal inhibitory concentration: 7580 nM
Compound 4: the middle estimate sits 2.5-fold (0.40 log units) below what was measured; the range from low to high includes it.
By their numbers in this assay, from the lowest: compound 1; then compounds 4, 3 and 2 (each within the scatter of the next).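

In this assay, putting 3-chlorophenyl on the nitrogen in place of 2-methoxyphenyl gives a 1.1-fold lower number from compound 3 to compound 4 (0.05 log units; within the scatter), and putting it in place of 4-methoxyphenyl gives a 1.2-fold lower number from compound 2 to compound 4 (0.06 log units; within the scatter), so these three groups cannot be told apart at this position when the other aryl group carries a methyl. The 3-chlorophenyl group alone therefore does not account for the low number of compound 1; with 3-chlorophenyl held fixed, methyl in place of isopropyl gives a 6.7-fold higher number from compound 1 to compound 4 (0.83 log units; beyond the scatter), which ties the difference to that other aryl group. No measurement here explains why this exchange matters while the nitrogen substituent does not.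

On these data alone, it remains open whether isopropyl gives a similar shift alongside either methoxyphenyl group. Also open, as far as these compounds go, is how an ethyl or a tert-butyl group would compare with methyl and isopropyl on that aryl ring.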